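Branched Alkyl to Cyclohexyl on the Benzimidazole Nitrogen

This account rests on a few compounds, and the source may have more. Where it says the series, first, only, none or still open, it means among the compounds named here.

Three measured compounds share a common core and differ mainly in the group on one ring nitrogen. Compound 1 `CC(C)c1onc(-c2c(Cl)cccc2Cl)c1COc1ccc(-c2nc3cc(C(=O)O)ccc3n2C)cc1` carries a methyl there and in an assay on Huh-7 cells for agonist activity at Bile acid receptor (Homo sapiens), read by a luciferase reporter (a lower number here means that less compound is needed, a higher number that more compound is needed for the effect), compound 1 gives 25.8 nM. Compound 3 `CC(C)c1onc(-c2c(Cl)cccc2Cl)c1COc1ccc(-c2nc3ccc(C(=O)O)cc3n2C)cc1Cl` also carries a methyl together with an added chlorine on the phenyl ether ring, and in this assay compound 3 gives 19 nM. Compound 2 `CCCC(CCC)n1c(-c2ccc(OCc3c(-c4c(Cl)cccc4Cl)noc3C(C)C)cc2)nc2ccc(C(=O)O)cc21` carries a 1-propylbutyl instead, and in this assay compound 2 gives 1.8 nM, the lowest of the three numbers, beyond the scatter from both compound 3 and compound 1.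

Compound 4 `CC(C)c1onc(-c2c(Cl)cccc2Cl)c1COc1ccc(-c2nc3ccc(C(=O)O)cc3n2C2CCCCC2)cc1` is the next candidate. Its change from compound 2 is cyclohexyl in place of 1-propylbutyl on an aromatic nitrogen. Within the data shown here, no measured pair isolates this change, so the direction rests on the closeness of the two groups in size alone. The step of a 1.7-fold higher number from compound 2 to compound 4 (0.22 log units; within the scatter) is expected to be small, with a slight lean toward a higher number. Compound 4 is estimated at 3 nM, within a range from 1 nM to 10 nM.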

Compound 4, half-maximal effective concentration: 4.21 nM
Beside the measured number, compound 4's estimate is 1.4-fold (0.15 log units) below it; the range from low to high includes it.
By their numbers in this assay, from the lowest: compound 2; then compound 4; then compounds 3 and 1 (each within the scatter of the next).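

In this assay, the change from an open chain to a ring on this aromatic nitrogen gives a 2.3-fold higher number from compound 2 to compound 4 (0.37 log units; beyond the scatter), a modest change but one beyond the scatter. Among these compounds, this is the first single-place comparison in the set, and it shows that the number at this position responds to the form of the group even when both groups are all carbon, carry no hydrogen-bond donors or acceptors, and have no net charge; compound 4 still gives 4.21 nM with the cyclohexyl ring in place. No measurement shown here accounts for this step.

The compounds shown do not separate the effect of closing the ring from that of changing the number of carbons. From the compounds shown here alone, how cyclopentyl or 1-ethylpropyl on the same nitrogen would compare with cyclohexyl and 1-propylbutyl remains open.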